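A few compounds are considered here, and "the series" means these few. Any claim that something is new, unique, unknown or untested is made for them only; others in the source may bear on it.

In a functional assay on WiDr cells (Homo sapiens) for antiproliferative activity, read by sulforhodamine B assay, with a stated time of 48 h (on this read-out lower numbers stand for stronger inhibition of growth and higher numbers for weaker inhibition of growth), compound 2, the structure `Cc1ccc(S(=O)(=O)N2CCC(Br)CC2)cc1`, is recorded only as a limit of the assay, namely > 100000 nM, and the measurement therefore gives no number for it; this is the situation described by the limit of > 100000 nM in this assay, at which 1 of the 2 values shown sits. Going by the values given here, compound 1, the structure `Cc1ccc(S(=O)(=O)N2CC[C@@H](Cl)C[C@@H]2C2CCCCC2)cc1`, is the one compound of the pair that carries a measured value, and in this assay compound 1 gives 15000 nM. Compound 3, the structure `Cc1ccc(S(=O)(=O)N2CC[C@@H](Br)C[C@@H]2C2CCCCC2)cc1`, has not yet been measured. Compound 3 differs from compound 2 by cyclohexyl in place of hydrogen on a saturated ring carbon. Among the compounds with values here, no measured step between two compounds that differ in one place is available here, so the size of this step can only be expected, not read off. The expectation is that the step from compound 2 to compound 3 is a move toward stronger inhibition of growth, and that this move is larger than the scatter, the estimated step being an at least 8.3-fold lower number from compound 2 to compound 3 (0.92 log units; beyond the scatter). On that basis compound 3 is expected to give about 12000 nM in this assay, within a range from 4000 nM to 40000 nM.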

Compound 3, concentration for 50% growth inhibition: 14000 nM
Compound 3: middle estimate off by 1.2-fold (0.07 log units), on the low side, and the stated range covers the measured number.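

In this assay, cyclohexyl in place of hydrogen on a saturated ring carbon, next to the ring nitrogen, gives an at least 7.1-fold lower number from compound 2 to compound 3 (0.85 log units; beyond the scatter), the first step read at this position, and it points toward stronger inhibition of growth. This step gives only a bound on the size of the change, since compound 2 is recorded only as a limit of the assay: the limit of > 100000 nM in this assay, at which 1 of the 3 values shown sits. The halogen, on the other hand, does not separate the two cyclohexyl-bearing compounds, as bromo in place of chloro on a saturated ring carbon gives a 1.1-fold lower number from compound 1 to compound 3 (0.03 log units; within the scatter), so among the compounds shown only the step that adds cyclohexyl lies beyond the scatter.

The compounds shown leave open whether this position needs cyclohexyl itself, or whether a methyl group, a phenyl ring or a longer chain at the same ring carbon would give a similar value. They also leave open how the read-out would respond if an amine or a carboxylic acid stood on the cyclohexyl ring, or if a hydroxyl group replaced the halogen.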